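Carboxy in Place of Hydroxy: an Expected Antiproliferative Readout

The source may hold more compounds than are shown below. What is called first, only, known or untested is meant among the compounds shown, and "the series" means these compounds.

Measured so far:
compound 1, `CCOc1ccc2nc(C(=O)Nc3c(F)cc(-c4cccc(F)c4)cc3F)c(C)c(O)c2c1`, gives 33.3% in a functional assay on Hep 3B2 cells (Homo sapiens) for antiproliferative activity, read by MTT assay, with a stated time of 24 h, tested at 100 ug/mL; a higher number here means a stronger effect of the compound at the concentration tested, a lower number a weaker effect
compound 2, `Cc1c(C(=O)Nc2c(F)cc(-c3cccc(F)c3)cc2F)nc2ccc(OC(F)(F)F)cc2c1O`, gives 80.3% in this assay
compound 3, `Cc1c(C(=O)Nc2c(F)cc(-c3cccc(F)c3)cc2F)nc2ccc(C(F)(F)F)cc2c1O`, gives 68.4% in this assay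

Compound 3 stands second highest of the three numbers: the step of a number 11.9 percentage points lower from compound 2 to compound 3 (beyond the scatter) separates it from compound 2, and the step of a number 35.1 percentage points higher from compound 1 to compound 3 (beyond the scatter) from compound 1. Compound 4, `Cc1c(C(=O)Nc2c(F)cc(-c3cccc(F)c3)cc2F)nc2ccc(C(F)(F)F)cc2c1C(=O)O`, differs from compound 3 by carboxy in place of hydroxy on an aromatic carbon. Going by the values given here, the three measured steps all concern the group that distinguishes compounds 1, 2 and 3 from one another; none touches the hydroxy group, so no measured step bears on this change, and the data give no direction for it. A step in this assay of any size, or none beyond the scatter, is therefore possible for compound 4. The expected step is a number 18.4 percentage points lower from compound 3 to compound 4 (beyond the scatter). Compound 4 is estimated at 50%, with a range from 15% to 80%.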

Compound 4, a percentage reported as inhibition, at one concentration (the size of the read-out at that concentration, not a potency): 72.3%
Compound 4: the middle estimate sits 22.3 percentage points below what was measured; low and high end bracket the measured number.
By their numbers in this assay, from the lowest: compound 1; then compounds 3, 4 and 2 (each within the scatter of the next, the first and the last beyond it).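

In this assay, the carboxy in place of hydroxy on this aromatic carbon, opposite the ring nitrogen, gives a number 3.9 percentage points higher from compound 3 to compound 4 (within the scatter), so the two groups cannot be told apart in this read-out. With trifluoromethyl on the shared core, hydroxy is thus not needed here for this level of effect at the concentration tested. Nothing measured explains this result. The compounds shown leave open whether an amine or a methyl ester at this position would read the same, and whether this exchange gives the same result with ethoxy or trifluoromethoxy on the core.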